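Hydroxymethyl in place of methoxycarbonyl at the ester position

The compounds below may be only part of what the source reports. "The series", "measured", "known", "first", "only" and "open" are said of these compounds alone.

The series is followed in a physicochemical assay for solubility, with a stated time of 4 h, at pH 2.0; a higher number here means a more soluble compound, a lower number a less soluble compound. Within the data shown here, compound 1 `COC(=O)c1cc(N)c(Nc2ccc(C#N)cc2)cc1Oc1c(C)cc(/C=C/C#N)cc1C` gives 1.75 ug/mL in this assay, the lowest of the two numbers known so far. Compound 2 `Cc1cc(CCC#N)cc(C)c1Oc1cc(Nc2ccc(C#N)cc2)c(N)cc1C(N)=O` gives 9.11 ug/mL in this assay, a higher number than compound 1, and the gap between the two lies beyond the usual scatter of repeated measurements.

Compound 3 `Cc1cc(/C=C/C#N)cc(C)c1Oc1cc(Nc2ccc(C#N)cc2)c(N)cc1CO` has not yet been measured in this assay. It differs from compound 1 in one place: hydroxymethyl in place of methoxycarbonyl on an aromatic carbon. The rest of the shared core, including the (4-cyanophenyl)amino group, the amino group and the side bearing the propenenitrile, is unchanged.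

Among the measured compounds shown here, no step between two measured compounds covers this particular change, so its size is not known from the data. The expected step from compound 1 to compound 3 in this assay is a 3.4-fold higher number from compound 1 to compound 3 (0.54 log units; beyond the scatter), upward and larger than the scatter. On that expectation compound 3 is estimated at 6 ug/mL in this assay, with a range from 2 ug/mL to 18 ug/mL.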

Compound 3, solubility: 20.9 ug/mL
Estimate against measurement, compound 3: 3.5-fold (0.54 log units) below; measured number outside the range, above it.
By their numbers in this assay, from the lowest: compound 1; then compound 2; then compound 3.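

At this position, on an aromatic carbon para to a (4-cyanophenyl)amino group, hydroxymethyl in place of methoxycarbonyl gives the only single-place step shown so far in this assay: a 12-fold higher number from compound 1 to compound 3 (1.08 log units; beyond the scatter). The step is large and shows that, with the rest of the shared core unchanged, including the amino group and the side bearing the propenenitrile, the group on this one carbon is enough to move the solubility number well beyond the usual scatter. Nothing available accounts for the size or direction of this step.

As far as these compounds go, a single pair cannot separate the loss of the methoxycarbonyl from the arrival of the hydroxymethyl, so it remains open which of the two exchanges carries the step and whether it would recur on a different core. A carboxylic acid, a methoxymethyl group or an aminomethyl group on the same aromatic carbon, with the rest of compound 1 kept, would show whether the number follows the hydroxyl, the loss of the carbonyl or something else about the group.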